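The source may report more compounds than this note shows. Statements on the series, on what has been measured and on what is new or still open speak of the compounds shown alone.

Working notes on the series. Compound 1 `COc1ccc(-c2nc(SCC(=O)c3sc(-c4ccccc4)nc3C)[nH]c(=O)c2C#N)cc1` gives 1.08% in a functional assay on U-87MG ATCC cells for antiproliferative activity against U-87 MG (Homo sapiens), read by MTT assay, with a stated time of 48 h, tested at 100 uM; a lower number here means a stronger effect, a higher number a weaker effect of the compound at the concentration tested. Compound 2 `COc1ccc(-c2nc(SCC(=O)c3sc(-c4ccc(Cl)cc4)nc3C)[nH]c(=O)c2C#N)cc1` carries the change (chloro in place of hydrogen on an aromatic carbon), and in this assay compound 2 gives 16.6%, a step of a number 15.5 percentage points higher from compound 1 to compound 2 (beyond the scatter). Compound 3 `COc1ccc(-c2nc(SCC(=O)c3sc(-c4ccccc4)nc3C)[nH]c(=O)c2C#N)cc1OC` differs from compound 1 in its core by methoxy in place of hydrogen on an aromatic carbon, and in this assay compound 3 gives 6.48%, a step of a number 5.4 percentage points higher from compound 1 to compound 3 (within the scatter). Among the measured compounds shown here, compound 4 `COc1ccc(-c2nc(SCC(=O)c3sc(-c4ccc(Cl)cc4)nc3C)[nH]c(=O)c2C#N)cc1OC` is not yet measured; it differs from compound 3 by chloro in place of hydrogen on an aromatic carbon, which is the same change as the one from compound 1 to compound 2, made on the core of compound 3 instead, with the place around it described in the same words. For the measured compounds named here, the step from compound 1 to compound 2 is the only measured instance of this change. On that single case, compound 4 is expected to show a step of a number 15.5 percentage points higher from compound 3 to compound 4 (beyond the scatter) in this assay, because the earlier instance gave a number 15.5 percentage points higher from compound 1 to compound 2 (beyond the scatter). Compound 4 is therefore estimated at 22%, with a range from 8% to 40%.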

Compound 4, a percentage reported as activity, at one concentration (the size of the read-out at that concentration, not a potency): 18.7%
Beside the measured number, compound 4's estimate is 3.3 percentage points above it, within the range that was stated.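

In this assay, the change from phenyl to 4-chlorophenyl gives a number 12.2 percentage points higher from compound 3 to compound 4 (beyond the scatter), and it carries from the core of compound 1 to the core of compound 3 with no difference in the size of the step: the same change on two cores in this assay, a number 15.5 percentage points higher (beyond the scatter) from compound 1 to compound 2 and a number 12.2 percentage points higher (beyond the scatter) from compound 3 to compound 4, 3.3 percentage points apart, within the scatter of two such steps The methoxy change, read on the chloro-bearing pair, gives a number 2.1 percentage points higher from compound 2 to compound 4 (within the scatter), and this step too does not differ from its earlier instance: the same change on two cores in this assay, a number 5.4 percentage points higher (within the scatter) from compound 1 to compound 3 and a number 2.1 percentage points higher (within the scatter) from compound 2 to compound 4, 3.3 percentage points apart, within the scatter of two such steps Across these four compounds the two changes therefore behave as independent of each other, but this rests on one pair of instances per change, at one concentration, with cores that differ only by one methoxy, and it shows neither a potency nor a reason for the chloro step.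

Open, on these data alone, is whether an amine or a carboxylic acid on the same aromatic carbon would give a step that carries in the same way. Also open, as far as these compounds go, is whether a longer chain in place of the added methoxy would leave the chloro step unchanged.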